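Swapping Amino for Nitro on a Weak Trypsin Inhibitor

This account rests on a few compounds, and the source may have more. Where it says the series, first, only, none or still open, it means among the compounds named here.

Of the compounds shown here, two have so far been tested in an assay on isolated protein for inhibition of serine protease 1 (Bos taurus); on this read-out higher numbers stand for weaker inhibition and lower numbers for stronger inhibition. Compound 1 `N=C(N)c1ccc(Cn2ccc3cc(C(=N)N)ccc32)c(Cl)c1` gives 5310 nM in this assay. Compound 2 `N=C(N)c1ccc2c(ccn2Cc2cccc(N)c2)c1` gives 16800 nM, the higher of the two numbers, a gap to compound 1 that lies beyond the usual scatter. Compound 3 `N=C(N)c1ccc2c(ccn2Cc2cccc([N+](=O)[O-])c2)c1` differs from compound 2 by one change: nitro in place of amino on an aromatic carbon. Among the measured compounds shown here, no measured pair shows what this swap does, so the step from compound 2 to compound 3 is expected to be small, a 1.3-fold higher number from compound 2 to compound 3 (0.12 log units; within the scatter), leaning toward weaker inhibition but hardly beyond the scatter. Compound 3 is therefore estimated at 22000 nM, within a range from 7000 nM to 70000 nM.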

Compound 3, inhibition constant: 7770 nM
Beside the measured number, compound 3's estimate is 2.8-fold (0.45 log units) above it; measured number inside the range.
By their numbers in this assay, from the lowest: compounds 1 and 3 (each within the scatter of the next); then compound 2.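

In this assay, putting nitro in place of amino gives a 2.2-fold lower number from compound 2 to compound 3 (0.33 log units; beyond the scatter), so the group on this aromatic carbon does affect the read-out. The amino group's hydrogen-bond donor is also not required for inhibition at this level, since nitro has none. Nothing measured here explains the direction of this step.

From the compounds shown here alone, whether a carboxylic acid, a nitrile or a methoxy group on the same carbon would lower the number further remains open. So does whether this swap would act the same way on a different core.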